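This account rests on a few compounds, and the source may have more. Where it says the series, first, only, none or still open, it means among the compounds named here.

In an ADME assay on L929 cells (Mus musculus) for cytotoxicity, read by resazurin assay, with a stated time of 96 h (a higher number here means that more compound is tolerated, a lower number that less compound is tolerated), compound 2 `COc1cccc(OC/C(=N\NC(N)=S)c2ccc(Br)cc2)c1` gives 50700 nM and compound 3 `CC(=O)Nc1ccc(OC/C(=N\NC(N)=S)c2ccc(Br)cc2)cc1` gives 94900 nM, two values within the scatter of each other. For compound 1 `Fc1ccc(/C(COc2ccc(Br)cc2)=N\NC(=S)Nc2ccccc2)cc1` the entry reads "not determined" (no result reported), so it adds no number for comparison. Compound 4 `NC(=S)N/N=C(\COc1ccc(I)cc1)c1ccc(Br)cc1` departs from compound 3 by iodo in place of acetamido on an aromatic carbon, para to a large group. Going by the values given here, no measured pair covers such a change, so any expectation for this assay remains loose. A moderate step of a 3.2-fold lower number from compound 3 to compound 4 (0.50 log units; beyond the scatter) toward a lower number is expected, though one within the scatter cannot be excluded. The estimated value for compound 4 is 30000 nM, with an expected range of 10000 nM to 80000 nM.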

Compound 4, half-maximal cytotoxic concentration: < 20400 nM
Compound 4 was reported as a limit (the forecaster's own chance of this, stated with the estimate: 10%); at least 1.4-fold (0.16 log units) between middle value and limit.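

Iodo in place of acetamido, para to a large group, gives the first step at this position that lies beyond the scatter in this assay, an at least 4.6-fold lower number from compound 3 to compound 4 (0.66 log units; beyond the scatter). Compound 4 gives < 20400 nM, which is a limit, so only the minimum size of this step is known. The reading rests on a single entry: the limit of < 20400 nM in this assay, at which 1 of the 4 values shown sits.

As far as these compounds go, whether the step follows from the arrival of iodo or the departure of acetamido stays open. So does the reading in this assay for chloro, an amine or a carboxylic acid at this position.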